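This account rests on a few compounds, and the source may have more. Where it says the series, first, only, none or still open, it means among the compounds named here.

Compound 2, `COc1cc(Cc2cnc(/N=C3\C(=O)N(CN4CCN(c5ccccn5)CC4)c4ccc(Cl)cc43)nc2N)cc(OC)c1OC`, is the point of departure. In an ADME assay on CCRF-CEM cells (Homo sapiens) for cytotoxicity, read by MTT assay, with a stated time of 5 days (on this read-out higher numbers stand for lower toxicity in this test and lower numbers for higher toxicity in this test), compound 2 gives 29.4 ug/mL, the lowest of the two numbers recorded for this series. Its nearest neighbour, compound 1, `COc1cc(Cc2cnc(/N=C3\C(=O)N(CN4CCN(c5ccc(F)cc5)CC4)c4ccc(Cl)cc43)nc2N)cc(OC)c1OC`, gives 71 ug/mL in this assay, and the step of a 2.4-fold lower number from compound 1 to compound 2 (0.38 log units; beyond the scatter) is beyond the scatter. Compound 3, `COc1cc(Cc2cnc(/N=C3\C(=O)N(CN4CCCCC4C)c4ccc(Cl)cc43)nc2N)cc(OC)c1OC`, returns only a limit in this assay, > 83.8 ug/mL, and it stands at the limit of > 83.8 ug/mL in this assay, at which 1 of the 3 values shown sits. The step of an at least 2.8-fold higher number from compound 2 to compound 3 (0.45 log units; beyond the scatter) is therefore at least modest.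

Compound 4, `COc1cc(Cc2cnc(/N=C3\C(=O)N(CN4CCN(c5cccc(Cl)c5)CC4)c4ccc(Cl)cc43)nc2N)cc(OC)c1OC`, has not yet been measured. The change from compound 2 is 3-chlorophenyl in place of pyridin-2-yl on an amine nitrogen in a ring. Among the measured steps, only a 2.4-fold lower number from compound 1 to compound 2 (0.38 log units; beyond the scatter) concerns a change of the aromatic group on the amine nitrogen of the ring, and it moved the number by a modest amount. A halogen-bearing phenyl returning in place of the pyridine is expected to move the number back toward the side of compound 1, so the step of a 1.9-fold higher number from compound 2 to compound 4 (0.27 log units; within the scatter) is estimated to be modest and upward. Compound 4 is thus expected to give about 55 ug/mL in this assay, most likely between 25 ug/mL and 100 ug/mL, pending measurement.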

Compound 4, half-maximal cytotoxic concentration: 34.4 ug/mL
Estimate against measurement, compound 4: 1.6-fold (0.20 log units) above; the range from low to high includes it.
By their numbers in this assay, from the lowest: compounds 2 and 4 (each within the scatter of the next); then compound 1. At a limit, above all of these: compound 3.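

At this position on the amine nitrogen in the ring, the aromatic ring can lose its ring nitrogen with no change that can be read in this assay: 3-chlorophenyl in place of pyridin-2-yl gives a 1.2-fold higher number from compound 2 to compound 4 (0.07 log units; within the scatter) and leaves the two compounds within the scatter of each other. The earlier step alone could have been read as a contrast between pyridin-2-yl and a ring of carbon only, but 3-chlorophenyl in place of 4-fluorophenyl gives a 2.1-fold lower number from compound 1 to compound 4 (0.31 log units; beyond the scatter) and so shows that two rings of carbon only, each bearing a halogen, need not give the same number here. Nothing in the data shown gives a reason for either result.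

The step between 4-fluorophenyl and 3-chlorophenyl changes both the halogen and its place on the ring, so it cannot say which of the two matters, and 4-chlorophenyl or 3-fluorophenyl on this nitrogen would separate them. Plain phenyl would show where the ring stands without any halogen, and whether pyridin-3-yl or pyridin-4-yl would match pyridin-2-yl also stays open.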